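The source may hold more compounds than are shown below. What is called first, only, known or untested is meant among the compounds shown, and "the series" means these compounds.

All three measured compounds were tested in a functional assay on HepG2 cells (Homo sapiens) for antiproliferative activity, read by MTT assay, with a stated time of 3 days; on this read-out lower numbers stand for stronger inhibition and higher numbers for weaker inhibition.

Compound 1, `CCCCCCC#Cc1cn(C/C=C/CN2C(=O)c3ccccc3C2=O)c(=O)[nH]c1=O`: 14000 nM
Compound 2, `CCCCc1ccc(C#Cc2cn(C/C=C\CN3C(=O)c4ccccc4C3=O)c(=O)[nH]c2=O)cc1`: 40000 nM
Compound 3, `O=C1c2ccccc2C(=O)N1C/C=C\Cn1cc(C#CCCc2ccccc2)c(=O)[nH]c1=O`: > 100000 nM (a limit of this assay, not a number)

Compound 1 holds the lowest of the two numbers, and the value of compound 2 stands higher than it by a gap beyond the usual scatter. Compound 3 is reported only as a limit (the limit of > 100000 nM in this assay, at which 1 of the 3 values shown sits). Among the compounds with values here, the single measured step, an at least 2.5-fold higher number from compound 2 to compound 3 (0.39 log units; beyond the scatter), changes the group on the triple-bonded carbon from an aryl to phenethyl and says nothing about lengthening a saturated chain, so no measured step bears directly on the move to compound 4, `CCCCCCCCC#Cc1cn(C/C=C/CN2C(=O)c3ccccc3C2=O)c(=O)[nH]c1=O`. That compound differs from compound 1 by ethyl in place of hydrogen on a saturated chain carbon, six bonds along the chain from a triple-bonded carbon. Within the data shown here, with no comparable step to lean on, the expectation is a change no larger than the scatter in this assay, that is, a step of about no change at the digits printed from compound 1 to compound 4 (within the scatter). Compound 4 is therefore estimated at 14000 nM, within a range from 5000 nM to 50000 nM.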

Compound 4, half-maximal inhibitory concentration: 43000 nM
Compound 4: middle estimate off by 3.1-fold (0.49 log units), on the low side, within the range that was stated.
By their numbers in this assay, from the lowest: compound 1; then compounds 2 and 4 (each within the scatter of the next). At a limit, above all of these: compound 3.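

In this assay, the step of a 3.1-fold higher number from compound 1 to compound 4 (0.49 log units; beyond the scatter) comes from ethyl in place of hydrogen on a saturated chain carbon, six bonds along the chain from a triple-bonded carbon. Within the data shown here, this shows that a change this far out along the chain is not silent in this assay, which the earlier compounds could not show, since their only measured step replaced an aryl group with phenethyl on the triple-bonded carbon. Nothing shown here accounts for the size or direction of this step.

From the compounds shown here alone, with a single pair, it remains open whether the number keeps rising with a still longer chain or falls with a shorter one such as butyl. Going by these compounds, it is equally open how a hydroxyl group or an amine at this same chain carbon would read.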